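The compounds below may be only part of what the source reports. "The series", "measured", "known", "first", "only" and "open" are said of these compounds alone.

Compound 1 `O=C(N/N=C/c1ccc(Cl)cc1)c1cnccn1` gives 56% in an ADME assay on J774 cells (Mus musculus) for cytotoxicity, read by MTT assay, with a stated time of 48 h, tested at 150 ug/mL (on this read-out higher numbers stand for a weaker effect at the one concentration tested and lower numbers for a stronger effect), the lowest of the three numbers measured there. Compound 2 `O=C(N/N=C/c1ccccc1F)c1cnccn1` gives 81% and compound 3 `O=C(N/N=C/c1cccc(Br)c1)c1cnccn1` gives 93% in this assay, both standing above compound 1 by more than the scatter. Compound 4 `COc1ccc(/C=N/NC(=O)c2cnccn2)cc1` has not yet been measured in this assay. It differs from compound 1 in one place: methoxy in place of chloro on an aromatic carbon. Going by the values given here, no pair of measured compounds shows what such a change does, so the expectation rests on the three values alone. Compound 4's expected shift is a number 19 percentage points higher from compound 1 to compound 4 (beyond the scatter), upward and beyond the scatter, because compound 1 gives 56% and sits at the low end of the range seen. Compound 4 is estimated at 75%, within 55% to 95%.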

Compound 4, a percentage reported as activity, at one concentration (the size of the read-out at that concentration, not a potency): 55%
For compound 4 the middle estimate is 20 percentage points above the measured one, and the stated range covers the measured number.
By their numbers in this assay, from the lowest: compounds 4 and 1 (each within the scatter of the next); then compound 2; then compound 3.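

At this position, on an aromatic carbon para to a large group, methoxy in place of chloro gives a number 1 percentage points lower from compound 1 to compound 4 (within the scatter) in this assay, so the read-out does not tell the two groups apart here. Methoxy brings a hydrogen-bond acceptor and chloro none, yet compound 4 stands within the scatter of compound 1. No measurement shown here accounts for this. From the compounds shown here alone, whether an amine or a carboxylic acid at this position would also stay within the scatter of compound 1 remains open. Also open, going by these compounds, is whether methoxy and chloro would match elsewhere on the ring.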